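The compounds below may be only part of what the source reports. "The series", "measured", "known", "first", "only" and "open" are said of these compounds alone.

Two esters of the shared core have been measured. Compound 1 `COC(=O)C1=C(C)NC(C)=C(C(=O)OC)C1c1[nH]cnc1Cl` gives 1200 nM in an assay on isolated protein for inhibition of Voltage-dependent L-type calcium channel subunit alpha-1C (Cavia porcellus) (on this read-out higher numbers stand for weaker inhibition and lower numbers for stronger inhibition), and compound 2 `CCOC(=O)C1=C(C)NC(C)=C(C(=O)OCC)C1c1[nH]cnc1Cl` gives 437 nM, the lowest of the two numbers; compound 1 stands a step above it that lies beyond the scatter. Compound 3 `CCOC(=O)C1=C(C)NC(C)=C(C(=O)OC)C1c1[nH]cnc1Cl` is the next member: relative to compound 2 it carries hydrogen in place of methyl on a saturated chain carbon bound to an oxygen next to a carbonyl group. Only one of the two esters changes here, so a partial return toward the number of compound 1 is expected, an upward step of a 1.6-fold higher number from compound 2 to compound 3 (0.20 log units; within the scatter) near the edge of the scatter. Compound 3 is estimated at 700 nM, within a range of 350 nM to 1400 nM.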

Compound 3, half-maximal inhibitory concentration: 661 nM
Compound 3: the middle estimate sits 1.1-fold (0.02 log units) above what was measured; low and high end bracket the measured number.
By their numbers in this assay, from the lowest: compounds 2, 3 and 1 (each within the scatter of the next, the first and the last beyond it).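

In this assay the change from ethoxycarbonyl to methoxycarbonyl on one ester gives a 1.5-fold higher number from compound 2 to compound 3 (0.18 log units; within the scatter) and the opposite change, from methoxycarbonyl to ethoxycarbonyl, gives a 1.8-fold lower number from compound 1 to compound 3 (0.26 log units; within the scatter) on the other ester. A single exchange at this position therefore stays within the scatter in both directions. No measurement on hand explains these steps.

Open, from the compounds shown here alone, is how a longer chain such as propyl or butyl on the ester oxygen would read. Also open, going by these compounds, is a carboxylic acid or an amide in place of either ester.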